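The source may hold more compounds than are shown below. What is called first, only, known or untested is meant among the compounds shown, and "the series" means these compounds.

Three compounds share one core. Compound 1 `CN(c1cccc2c1CCCC2c1c[nH]cn1)S(C)(=O)=O` gives 912 nM in an assay on isolated protein for binding affinity to Alpha-2B adrenergic receptor (Rattus norvegicus), read by radioligand binding (on this read-out higher numbers stand for weaker inhibition and lower numbers for stronger inhibition), compound 2 `O=C(Nc1cccc2c1CCCC2c1c[nH]cn1)C(F)(F)F` gives 661 nM, and compound 3 `Oc1cccc2c1CCCC2c1c[nH]cn1` gives 3.8 nM. Compound 2 thus stands second highest of the three: a 1.4-fold lower number from compound 1 to compound 2 (0.14 log units; within the scatter), whereas compound 3 sits far lower. Compound 4 `Nc1cccc2c1CCCC2c1c[nH]cn1` is not yet measured; it carries hydrogen in place of (trifluoromethyl)carbonyl on a nitrogen on an aromatic ring, so the same difference, cut one bond further out, reads ((trifluoromethyl)carbonyl)amino to amino. Among the measured compounds shown here, the steps that bear on this are a 170-fold lower number from compound 2 to compound 3 (2.24 log units; beyond the scatter) and a 240-fold lower number from compound 1 to compound 3 (2.38 log units; beyond the scatter), both large, each exchanging a substituted nitrogen for hydroxy. An amino group is expected to sit closer to that hydroxy, so a large drop is expected: a 26-fold lower number from compound 2 to compound 4 (1.42 log units; beyond the scatter). Compound 4 is therefore estimated at 25 nM, from 4 nM to 150 nM as its range.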

Compound 4, inhibition constant: 49 nM
For compound 4 the middle estimate is 2.0-fold (0.29 log units) below the measured one; measured number inside the range.
By their numbers in this assay, from the lowest: compound 3; then compound 4; then compounds 2 and 1 (each within the scatter of the next).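

In this assay a plain amino group clearly outdoes both substituted nitrogens, with a 13-fold lower number from compound 2 to compound 4 (1.13 log units; beyond the scatter) on removing the (trifluoromethyl)carbonyl and a 19-fold lower number from compound 1 to compound 4 (1.27 log units; beyond the scatter) on replacing the methyl(methylsulfonyl)amino, so much of their high numbers goes with what the nitrogen carries. Amino still falls short of hydroxy, with a 13-fold higher number from compound 3 to compound 4 (1.11 log units; beyond the scatter) on the same aromatic carbon, so the atom attached there counts as well. Nothing measured here says why these changes act as they do.

Open, on these data alone, is where a methylamino or a methoxy group on that carbon would fall relative to amino and hydroxy. Also open, as far as these compounds go, is whether a plain acetyl on the nitrogen would read like the (trifluoromethyl)carbonyl.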